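Removing the Remaining Ring Alkyl Group: Cytotoxicity Outlook

The compounds below may be only part of what the source reports. "The series", "measured", "known", "first", "only" and "open" are said of these compounds alone.

Of the compounds shown here, three built on one shared core have been tested in an ADME assay on MDCK cells (Canis lupus familiaris) for cytotoxicity, read by microscopy, with a stated time of 48 h; on this read-out higher numbers stand for lower toxicity in this test and lower numbers for higher toxicity in this test. Compound 1 `C[C@H]1[C@H](NCc2ccc(C(C)(C)C)s2)C[C@H]2C[C@@H]1C2(C)C` gives 780 nM. Going by the values given here, compound 3 `CCc1ccc(CN[C@@H]2C[C@H]3C[C@@H]([C@H]2C)C3(C)C)s1` gives 1560 nM, with compound 1 as its nearest neighbour among the numbers obtained, and the step of a 2.0-fold higher number from compound 1 to compound 3 (0.30 log units; within the scatter) is the only measured change at a single position in this set. Compound 2 `C[C@H]1[C@H](NCc2cncs2)C[C@H]2C[C@@H]1C2(C)C` reaches only a limit of the assay, > 100000 nM. The summary the limit of > 100000 nM in this assay, at which 1 of the 3 values shown sits, records that one of the three results sits at that limit.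

Compound 4 `C[C@H]1[C@H](NCc2cccs2)C[C@H]2C[C@@H]1C2(C)C` has not yet been measured. It differs from compound 3 in one place: hydrogen in place of ethyl on an aromatic carbon. Among the compounds with values here, the measured step from compound 1 to compound 3 also altered the group on that aromatic carbon and stayed within the scatter, so no measured step in this set directly covers the complete removal of the ethyl group; the one known step points, if anything, toward a higher number. Compound 4 is therefore expected to give 4000 nM, between 1500 nM and 12000 nM. That estimate corresponds to an expected step of a 2.6-fold higher number from compound 3 to compound 4 (0.41 log units; beyond the scatter), which is a forecast rather than a measurement.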

Compound 4, minimum cytotoxic concentration: 25000 nM
Beside the measured number, compound 4's estimate is 6.3-fold (0.80 log units) below it, outside the stated range (above it).
By their numbers in this assay, from the lowest: compounds 1 and 3 (each within the scatter of the next); then compound 4. At a limit, above all of these: compound 2.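

Going by these compounds alone, on the aromatic carbon next to the ring sulfur, the earlier compounds showed only that ethyl and tert-butyl could not be told apart in this assay, whereas replacing either group with hydrogen gives a 16-fold higher number from compound 3 to compound 4 (1.20 log units; beyond the scatter) and a 32-fold higher number from compound 1 to compound 4 (1.51 log units; beyond the scatter). Among these three compounds, then, the large change comes with losing the alkyl group altogether, not with exchanging one of these two alkyl groups for the other. With no alkyl group on either ring, thiophen-2-yl in place of 1,3-thiazol-5-yl on the saturated chain carbon bound to the amine nitrogen gives an at least 4.0-fold lower number from compound 2 to compound 4 (0.60 log units; beyond the scatter), and that step is only a minimum, as the result for compound 2 is a limit and not a number: the limit of > 100000 nM in this assay, at which 1 of the 4 values shown sits.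

The compounds shown leave open whether a methyl group, a chlorine atom or a methoxy group on this aromatic carbon would give a number closer to that of compound 3 or to that of compound 4. They also leave open whether an ethyl group on the 1,3-thiazol-5-yl ring would lower the number as it does on the ring of compound 3, and they give no reason for the size of these steps.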